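This account rests on a few compounds, and the source may have more. Where it says the series, first, only, none or still open, it means among the compounds named here.

Measured compounds:
compound 1 `Oc1ccc(C2C/C(=N\NC(=S)N3CCCCC3)c3ccc(O)cc3O2)cc1` — 74400 nM
compound 2 `Oc1ccc(C2C/C(=N\NC(=S)N3CCOCC3)c3ccc(O)cc3O2)cc1` — 76300 nM

Both compounds were tested in a functional assay on HeLa cells (Homo sapiens) for cytotoxicity, read by MTT assay, with a stated time of 72 h; a lower number here means a stronger inhibitor, a higher number a weaker inhibitor. On the numbers shown, compound 2 stands level with compound 1: the only recorded step, a 1.0-fold higher number from compound 1 to compound 2 (0.01 log units; within the scatter), is within the scatter, so these two compounds cannot be told apart by this measurement.

Compound 3 `CCCCNC(=S)N/N=C1\CC(c2ccc(O)cc2)Oc2cc(O)ccc21` has not yet been measured. It differs from compound 2 in one place: butylamino in place of morpholin-4-yl on a thiocarbonyl carbon. Within the data shown here, the one measured step bears on this change only loosely, since it swapped one six-membered ring for another on the thiocarbonyl carbon, whereas here a ring gives way to an open chain with a hydrogen-bond donor. That earlier step, a 1.0-fold higher number from compound 1 to compound 2 (0.01 log units; within the scatter), produced no movement beyond the scatter, so the simplest expectation is that the thiocarbonyl substituent has little influence on this read-out, and the step from compound 2 to compound 3 is expected to be small as well, a 1.3-fold lower number from compound 2 to compound 3 (0.10 log units; within the scatter). Compound 3 is therefore estimated at 60000 nM, with a range from 25000 nM to 150000 nM.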

Compound 3, half-maximal inhibitory concentration: > 100000 nM
Compound 3 ended at the assay's limit (the forecaster's own chance of this, stated with the estimate: 15%); at least 1.6-fold (0.22 log units) between middle value and limit.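

In this assay, compound 3 gives a limit of the assay, not a number: the limit of > 100000 nM in this assay, at which 1 of the 3 values shown sits.

Putting the open butylamino chain on the thiocarbonyl carbon in place of a ring gives an at least 1.3-fold higher number from compound 2 to compound 3 (0.11 log units; that floor lies within the scatter), and the comparison with the piperidin-1-yl compound gives an at least 1.3-fold higher number from compound 1 to compound 3 (0.12 log units; that floor lies within the scatter). From the compounds shown here alone, both figures are only floors, and both floors lie within the scatter, so the true size of each step stays unknown, and compound 3 may sit close to the two ring compounds or well beyond them. What the two ring compounds could not show is that swapping a ring for an open chain with a hydrogen-bond donor at this position brings no stronger inhibition in these cells.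

Going by these compounds, with no number for compound 3, it remains open whether the chain itself costs activity or whether this position simply matters little for the read-out. Also open, on these data alone, is how a dimethylamino group, a phenylamino group or a longer chain such as octylamino would read on the same thiocarbonyl carbon, and any of these could show whether this position can move the value at all.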